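Removing the halogen: a small step on a weak chromone series

This account rests on a few compounds, and the source may have more. Where it says the series, first, only, none or still open, it means among the compounds named here.

Measured so far in a functional assay on A549 cells (Homo sapiens) for inhibition, read by sulforhodamine B assay, with a stated time of 48 h; a lower number here means a stronger inhibitor, a higher number a weaker inhibitor:
- compound 1, `O=c1c(C2N=C(c3ccccc3)SS2)coc2ccc(Cl)cc12`, gives 71300 nM
- compound 2, `O=c1c(C2N=C(c3ccccc3)SS2)coc2ccc(F)cc12`, gives 91100 nM

Both numbers are high, so both compounds are weak inhibitors. Among the compounds with values here, compound 2 holds the highest of the two numbers; its nearest neighbour is compound 1, and the only step measured so far, a 1.3-fold higher number from compound 1 to compound 2 (0.11 log units; within the scatter), lies within the scatter. Nothing here separates the two compounds with confidence.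

Compound 3, `O=c1c(C2N=C(c3ccccc3)SS2)coc2ccccc12`, differs from compound 2 in one place: hydrogen in place of fluoro on an aromatic carbon. Within the data shown here, the one step that bears on this change is the swap of chloro for fluoro at the same position, a 1.3-fold higher number from compound 1 to compound 2 (0.11 log units; within the scatter), which was too small to count. That step says little about what the loss of the halogen altogether will do, but it gives no sign that this position is sensitive.

On that basis the expected step from compound 2 to compound 3 in this assay is a 1.1-fold higher number from compound 2 to compound 3 (0.04 log units; within the scatter), with no change beyond the scatter. Compound 3 is therefore estimated at 100000 nM, with a likely range from 40000 nM to 250000 nM.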

Compound 3, half-maximal inhibitory concentration: > 100000 nM
Compound 3 ended at the assay's limit; the forecaster's own chance of this, stated with the estimate: 20%; the middle value sits exactly at the limit.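

In this assay compound 3 gives > 100000 nM, which is a limit of the assay and not a number. The steps that reach it can therefore be read only as floors: for hydrogen in place of fluoro the step is an at least 1.0-fold higher number from compound 2 to compound 3 (0.04 log units; that floor lies within the scatter), and for hydrogen in place of chloro it is an at least 1.4-fold higher number from compound 1 to compound 3 (0.14 log units; that floor lies within the scatter). What this adds is that removing the halogen altogether brings no low number at this position, while the true size of the change stays hidden, since the real value of compound 3 could sit close to the limit or far past it: the limit of > 100000 nM in this assay, at which 1 of the 3 values shown sits.

The compounds shown leave open whether any other group on this aromatic carbon, such as an amine, a methoxy group or a carboxylic acid, would bring the number down, as this position has so far carried only chloro, fluoro and hydrogen. They also leave open whether a change elsewhere on the shared core would count for more than any change made here.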